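A few compounds are considered here, and "the series" means these few. Any claim that something is new, unique, unknown or untested is made for them only; others in the source may bear on it.

Values measured in a functional assay on DU-145 cells (Homo sapiens) for cytotoxicity, read by MTT assay (a lower number here means a stronger inhibitor, a higher number a weaker inhibitor), are as follows
- compound 1 `CC(C)=CC[C@@H](OC[C@@H](C)O)C1=CC(=O)c2c(O)ccc(O)c2C1=O` gives 14300 nM
- compound 2 `CC[C@](C)(O)CC(=O)O[C@H](CC=C(C)C)C1=CC(=O)c2c(O)ccc(O)c2C1=O` gives 20500 nM

For the measured compounds named here, of only two numbers, compound 2 at 20500 nM is not separated from compound 1 because a 1.4-fold higher number from compound 1 to compound 2 (0.16 log units; within the scatter) is within the scatter. Compound 3 `CCC(O)CO[C@H](CC=C(C)C)C1=CC(=O)c2c(O)ccc(O)c2C1=O` follows from compound 2 by this change (2-hydroxybutyl in place of (2-hydroxy-2-methylbutyl)carbonyl on an oxygen on a saturated carbon). In words, 2-hydroxybutyl stands in place of (2-hydroxy-2-methylbutyl)carbonyl on an oxygen on a saturated carbon. Going by the values given here, the one measured step at this place is a 1.4-fold higher number from compound 1 to compound 2 (0.16 log units; within the scatter), which exchanged 2-hydroxypropyl for (2-hydroxy-2-methylbutyl)carbonyl without leaving the scatter. The entering 2-hydroxybutyl resembles the 2-hydroxypropyl of compound 1, which gives 14300 nM. No direction is therefore expected, and the estimated step of a 1.4-fold lower number from compound 2 to compound 3 (0.14 log units; within the scatter) should stay within the scatter in this assay. For compound 3 the expected value is 15000 nM, with an estimated range of 7000 nM to 32000 nM.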

Compound 3, half-maximal inhibitory concentration: 16400 nM
For compound 3 the middle estimate is 1.1-fold (0.04 log units) below the measured one; low and high end bracket the measured number.
By their numbers in this assay, from the lowest: compounds 1, 3 and 2 (each within the scatter of the next).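

In this assay, 2-hydroxybutyl in place of (2-hydroxy-2-methylbutyl)carbonyl on an oxygen on a saturated carbon gives a 1.3-fold lower number from compound 2 to compound 3 (0.10 log units; within the scatter). At this position, the exchange of a group of 8 heavy atoms with a carbonyl for one of 5 heavy atoms without a carbonyl therefore stays within the scatter. The smaller change of 1-hydroxypropyl in place of 1-hydroxyethyl on a saturated chain carbon bound to an oxygen on a saturated carbon gives a 1.1-fold higher number from compound 1 to compound 3 (0.06 log units; within the scatter), so this one-carbon difference in the chain also leaves the number within the scatter.

The compounds shown leave open whether a primary amine, a carboxylic acid or a much longer alkyl chain on this oxygen would move the number beyond the scatter. No measurement is available that could explain the flatness of these steps.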